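Chloro to hydrogen on the shared core

A few compounds are considered here, and "the series" means these few. Any claim that something is new, unique, unknown or untested is made for them only; others in the source may bear on it.

Working notes on the series: compound 1 `COc1cc(Nc2nc(Cl)cc3c(C(C)C)n[nH]c23)cc(OC)c1OC`, compound 2 `N#Cc1cc2c(-c3ccccc3)n[nH]c2c(Nc2ccccc2)n1` and compound 3 `COc1cc(Nc2nc(Cl)cc3c(-c4ccccc4)n[nH]c23)cc(OC)c1OC` have been measured; compound 4 `COc1cc(Nc2nccc3c(-c4ccccc4)n[nH]c23)cc(OC)c1OC` has not. In an assay on Flp-In-CHO cells for binding affinity to adenosine receptor A3 (Homo sapiens), read by NanoBRET (on this read-out lower numbers stand for stronger inhibition and higher numbers for weaker inhibition), compound 1 gives 631 nM, compound 2 gives 43.7 nM and compound 3 gives 55 nM, so compound 3 stands second highest of the three numbers, with compound 2 within the scatter of it and compound 1 well above.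

Within the data shown here, the one step recorded, an 11-fold lower number from compound 1 to compound 3 (1.06 log units; beyond the scatter), concerns the group on the shared core, not the change considered here. Compound 4 differs from compound 3 by hydrogen in place of chloro on an aromatic carbon, at the place on an aromatic carbon of a six-membered aromatic ring with one nitrogen, part of a fused or bridged system of two rings, next to the ring nitrogen. Among the measured compounds shown here, no measured step of this kind exists; compound 2 carries a nitrile at that place but also a different amine, so its value only shows that the position tolerates substitution.

For compound 4 in this assay the expected outcome is a modest rise, a 2.7-fold higher number from compound 3 to compound 4 (0.44 log units; beyond the scatter), giving an estimate of 150 nM within 50 nM to 500 nM.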

Compound 4, inhibition constant: 100 nM
Compound 4: middle estimate off by 1.5-fold (0.18 log units), on the high side; the range from low to high includes it.
By their numbers in this assay, from the lowest: compounds 2, 3 and 4 (each within the scatter of the next, the first and the last beyond it); then compound 1.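

In this assay, among these compounds, hydrogen in place of chloro gives a 1.8-fold higher number from compound 3 to compound 4 (0.26 log units; within the scatter) and is the first reading of this change on an aromatic carbon next to the ring nitrogen. With the rest of the molecule held constant, chloro at this place is therefore not shown to be required for the measured binding, a point that compound 2 could not settle because it also differs in its amine. Nothing measured here explains this result.

On these data alone, whether an amine, a methoxy group or a carboxylic acid at this place would also stay within the scatter of hydrogen and chloro remains open. As far as these compounds go, it is also open whether hydrogen and chloro would stay as close with isopropyl in place of phenyl on the shared core.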